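A few compounds are considered here, and "the series" means these few. Any claim that something is new, unique, unknown or untested is made for them only; others in the source may bear on it.

In an ADME assay on HEK-293T cells (Homo sapiens) for inhibition, read by CCK-8 assay, with a stated time of 48 h, tested at 20 uM (a lower number here means less inhibition of growth, a higher number more inhibition of growth at the concentration tested), compound 1 (`COc1ccc(Cc2nnc(NC(=O)/C(C#N)=C/c3ccccc3OS(=O)(=O)c3ccc(OC)cc3)s2)cc1`) gives 30% and compound 2 (`Cc1ccc(S(=O)(=O)Oc2ccccc2/C=C(\C#N)C(=O)Nc2nnc(Cc3cccc4ccccc34)s2)cc1`) gives 23% and these two values lie within the scatter of each other. Compound 3 (`COc1ccc(S(=O)(=O)Oc2ccccc2/C=C(\C#N)C(=O)Nc2nnc(Cc3cccc4ccccc34)s2)cc1`) is compound 2 with methoxy in place of methyl on an aromatic carbon, para to a large group (methoxy in place of methyl on an aromatic carbon). Within the data shown here, no measured pair isolates this change, so the data give no direct size for it. Compound 1 also carries the (4-methoxyphenyl)sulfonyl group and gives 30% but differs from compound 3 elsewhere as well. No step beyond the scatter is therefore expected in this assay for this change. The estimated step is small (a number 2 percentage points higher from compound 2 to compound 3 (within the scatter)). Compound 3 is expected to give 25% (13% to 38%).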

Compound 3, percent growth inhibition at one concentration: 29%
Compound 3: middle estimate off by 4 percentage points, on the low side; the measured number falls inside the stated range.
By their numbers in this assay, from the lowest: compounds 2, 3 and 1 (each within the scatter of the next).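

In this assay, among these compounds, methoxy in place of methyl on an aromatic carbon, para to a large group, gives a number 6 percentage points higher from compound 2 to compound 3 (within the scatter), the first direct reading of this change, so the exchange of these two groups at this position registers no step beyond the scatter. The pair sharing the (4-methoxyphenyl)sulfonyl group adds a second direct reading at another place: naphthalen-1-yl in place of 4-methoxyphenyl on a saturated chain carbon bound to an aromatic carbon gives a number 1 percentage points lower from compound 1 to compound 3 (within the scatter), which also stays within the scatter. No measured property bears on either step.

Open, from the compounds shown here alone, is whether a group of another kind at the para position, such as an amine or a carboxylic acid, would give a step beyond the scatter. Also open, going by these compounds, is whether a longer chain in place of the saturated chain carbon would do so.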